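One group exchanged on the lowest-scoring compound

The source may hold more compounds than are shown below. What is called first, only, known or untested is meant among the compounds shown, and "the series" means these compounds.

So far, three compounds have been measured. Compound 1 `COc1cc(C)nc2n/c(=N/C(=O)c3c(-c4ccc(Cl)cc4Cl)noc3C)sn12` reaches 45.7% in a functional assay on the whole organism for inhibition, with Chenopodium ficifolium as the target, with a stated time of 72 h, tested at 10 mg/L; a higher number here means more inhibition of growth at the concentration tested, a lower number less inhibition of growth. Among the measured compounds shown here, compound 3 `CSc1cc(C)nc2n/c(=N/C(=O)c3c(-c4ccc(Cl)cc4Cl)noc3C)sn12` gives 21.9% in this assay, and the one measured step between them, methylsulfanyl in place of methoxy on an aromatic carbon, reads a number 23.8 percentage points lower from compound 1 to compound 3 (beyond the scatter). Compound 2 `COc1cc(SC)nc(NC(=S)NC(=O)c2c(-c3ccc(Cl)cc3Cl)noc2C)n1` stands lowest of the three with -8.31% in this assay, far from both others, and it carries a different linking portion than compound 1 and compound 3.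

Compound 4 `COc1cc(OC)nc(NC(=S)NC(=O)c2c(-c3ccc(Cl)cc3Cl)noc2C)n1` is not yet measured. It differs from compound 2 in one place: methoxy in place of methylsulfanyl on an aromatic carbon. For the measured compounds named here, this is the reverse of the only step seen so far, which lowered inhibition from compound 1 to compound 3. Running that exchange backwards, an increase of similar size is the natural expectation, though the two cores are not the same, so the transfer is uncertain.

The expected result for compound 4 is therefore a rise of a number 20.3 percentage points higher from compound 2 to compound 4 (beyond the scatter) in this assay. Compound 4 is estimated at 12%, within a range from -10% to 35%.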

Compound 4, percent growth inhibition at one concentration: 30.7%
Compound 4: middle estimate off by 18.7 percentage points, on the low side; measured number inside the range.
By their numbers in this assay, from the lowest: compound 2; then compounds 3 and 4 (each within the scatter of the next); then compound 1.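

Going from 4-methoxy-6-(methylsulfanyl)pyrimidin-2-yl to 4,6-dimethoxypyrimidin-2-yl gives a number 39 percentage points higher from compound 2 to compound 4 (beyond the scatter) in this assay, so on this second core, too, the compound carrying methoxy stands higher than the one carrying methylsulfanyl. The direction of this exchange, which rested on a single pair before, now holds in both pairs shown, and neither pair goes against it, although two pairs are still a small basis for any pattern. The size of the step, however, does not carry over unchanged from one core to the other: the same change on two cores in this assay, a number 23.8 percentage points lower (beyond the scatter) from compound 1 to compound 3 and a number 39 percentage points lower (beyond the scatter) from compound 4 to compound 2, 15.2 percentage points apart, beyond the scatter of two such steps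

Still open is which difference between the two cores sets the size of the step: they differ in the linking portion and also in the other group on the six-membered aromatic ring, and the compounds shown do not separate these two differences. Also open, from the compounds shown here alone, is how this position responds to groups other than methoxy and methylsulfanyl, such as an amine, a chlorine atom or the longer ethoxy chain, on either core.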